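The source may report more compounds than this note shows. Statements on the series, on what has been measured and on what is new or still open speak of the compounds shown alone.

Measured in a functional assay for inhibition, with Homo sapiens as the target; a higher number here means a weaker inhibitor, a lower number a stronger inhibitor:

Compound 1 `COC(=O)[C@H](CC1CCCCC1)Nc1nc2ccccc2o1`: 5 nM
Compound 2 `c1ccc(C(CC2CCCCC2)Nc2nc3ccccc3o2)cc1`: 340 nM; 8 nM; 6 nM (3 entries)
Compound 3 `Fc1ccc(C(CC2CCCCC2)Nc2nc3ccccc3o2)cc1`: 170 nM

Of the two compounds with a single number, compound 1 gives 5 nM, while compound 3 gives the higher number, 170 nM, a gap beyond the scatter. This makes compound 3 the weaker inhibitor of that pair. Compound 2 has no single number, and its entries of 340 nM; 8 nM; 6 nM (3 entries) do not agree with one another.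

Compound 4 `COc1ccc(C(CC2CCCCC2)Nc2nc3ccccc3o2)cc1` has methoxy in place of fluoro on an aromatic carbon, para to a large group (methoxy in place of fluoro on an aromatic carbon). Among the measured compounds shown here, no measured pair shows this change, so no step beyond the scatter is expected in this assay, and no direction is favoured. The expected change is a 1.3-fold lower number from compound 3 to compound 4 (0.12 log units; within the scatter). The range is kept wide because the several entries of compound 2 in this assay, 340 nM; 8 nM; 6 nM (3 entries) show how far results for a close relative can spread. Compound 4 is expected at 130 nM, with an estimated range of 20 nM to 600 nM.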

Compound 4, half-maximal inhibitory concentration: 550 nM
For compound 4 the middle estimate is 4.2-fold (0.63 log units) below the measured one, and the stated range covers the measured number.
By their numbers in this assay, from the lowest: compound 1; then compound 3; then compound 4.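

In this assay, putting methoxy in place of fluoro on an aromatic carbon, para to a large group, gives a 3.2-fold higher number from compound 3 to compound 4 (0.51 log units; beyond the scatter). Among the compounds shown here, this is the only measured pair here that differs in one place, and it shows that the number responds to the group at this position, with compound 4 the weaker inhibitor of the two. The step is modest and should be read against how far results for a close relative can spread: the several entries of compound 2 in this assay, 340 nM; 8 nM; 6 nM (3 entries)

From the compounds shown here alone, whether a chloro, hydroxyl or amino group at this position would give a number nearer to that of compound 3 or of compound 4 remains open. Going by these compounds, as compound 2 has no single number, it also remains open how far either fluoro or methoxy moves the number from that of the unsubstituted ring.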